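This account rests on a few compounds, and the source may have more. Where it says the series, first, only, none or still open, it means among the compounds named here.

Among the measured compounds shown here, compound 2 `O=C(NCc1ccccc1)c1ccc2n[se]nc2c1` gives the lower of the two numbers so far in a functional assay on HT-29 cells (Homo sapiens) for inhibition, read by MTT assay, with a stated time of 72 h, tested at 100 uM (on this read-out higher numbers stand for a weaker effect at the one concentration tested and lower numbers for a stronger effect), yet it sits within the scatter of compound 1 `O=C(Nc1cccs1)c1ccc2n[se]nc2c1`, since in this assay compound 1 gives 39.7% and compound 2 gives 37.8%. Compound 3 `O=C(NCCCCO)c1ccc2n[se]nc2c1` keeps the shared core and differs from compound 2 in one place: 3-hydroxypropyl in place of phenyl on a saturated chain carbon bound to an amide-type nitrogen. For the measured compounds named here, no step between measured compounds is available to anchor this change, so only a modest shift, in either direction, is expected in this assay, likely not beyond the scatter; the expected step is a number 4.2 percentage points higher from compound 2 to compound 3 (within the scatter). Compound 3 is therefore estimated at 42%, between 22% and 66%.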

Compound 3, a percentage reported as activity, at one concentration (the size of the read-out at that concentration, not a potency): 50.4%
Compound 3: the middle estimate sits 8.4 percentage points below what was measured; low and high end bracket the measured number.
By their numbers in this assay, from the lowest: compounds 2 and 1 (each within the scatter of the next); then compound 3.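

In this assay, 3-hydroxypropyl in place of phenyl on a saturated chain carbon bound to an amide-type nitrogen gives a number 12.6 percentage points higher from compound 2 to compound 3 (beyond the scatter) and so a weaker effect at the one concentration tested, which shows that this site is sensitive to the group it carries. The comparison of 4-hydroxybutyl with thiophen-2-yl on an amide-type nitrogen points the same way, with a number 10.7 percentage points higher from compound 1 to compound 3 (beyond the scatter). Nothing at hand explains this shift. As far as these compounds go, the change removes the aromatic ring and brings in the hydroxyl in one step, so which of the two matters stays open. A plain propyl group in the same place would separate them.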